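The source may hold more compounds than are shown below. What is called first, only, known or untested is meant among the compounds shown, and "the series" means these compounds.

Compound 1 `CC(C)(C)c1ccc(CNCCCNS(=O)(=O)c2cc(C(F)(F)F)cc(C(F)(F)F)c2)cc1`: 2700 nM
Compound 2 `O=S(=O)(NCCCNCc1cccc(Cl)c1)c1cc(C(F)(F)F)cc(C(F)(F)F)c1`: 5900 nM

In a functional assay on ASPC1 cells (Homo sapiens) for inhibition, read by MTT assay, with a stated time of 72 h (a higher number here means a weaker inhibitor of growth, a lower number a stronger inhibitor of growth), compound 2 stands at the higher of the two numbers, set apart from compound 1 by the step of a 2.2-fold higher number from compound 1 to compound 2 (0.34 log units; beyond the scatter). Compound 3 `COc1cccc(CNCCCNS(=O)(=O)c2cc(C(F)(F)F)cc(C(F)(F)F)c2)c1` differs from compound 2 by methoxy in place of chloro on an aromatic carbon. Among the compounds with values here, no measured step covers this exchange directly. Within the data shown here, the only step known, a 2.2-fold higher number from compound 1 to compound 2 (0.34 log units; beyond the scatter), replaces the whole aryl group and was modest, so a change of at most a similar size is expected here, with no clear direction. Compound 3 is therefore estimated at 5000 nM, within 2000 nM to 14000 nM, which means an expected step of a 1.2-fold lower number from compound 2 to compound 3 (0.07 log units; within the scatter).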

Compound 3, concentration for 50% growth inhibition: 3800 nM
For compound 3 the middle estimate is 1.3-fold (0.12 log units) above the measured one; the range from low to high includes it.
By their numbers in this assay, from the lowest: compounds 1, 3 and 2 (each within the scatter of the next, the first and the last beyond it).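

In this assay the exchange of chloro for methoxy on this aromatic carbon gives a 1.6-fold lower number from compound 2 to compound 3 (0.19 log units; within the scatter) and so stays within the scatter. The 3-methoxyphenyl group, with a 1.4-fold higher number from compound 1 to compound 3 (0.15 log units; within the scatter) as its step, also stays within the scatter of the 4-(tert-butyl)phenyl group, which the 3-chlorophenyl group of compound 2 did not. Nothing measured here gives a reason for this result.

Still open, as far as these compounds go, is whether a nitrile, an amine or a carboxylic acid on this aromatic carbon would keep the number in the same range. A longer chain between the sulfonamide and the amine nitrogen is also left open.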